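Homologation of the cyclohexylamine link from compound 2

A few compounds are considered here, and "the series" means these few. Any claim that something is new, unique, unknown or untested is made for them only; others in the source may bear on it.

Compound 1 `CO[C@H]1CC[C@@H](Nc2cc(NCc3cnccc3C(F)(F)F)ncc2C#N)CC1` gives 5000 nM in an assay on isolated protein for inhibition of protein kinase C delta type (Homo sapiens), read by TR-FRET, with a stated time of 2 h; a lower number here means a stronger inhibitor, a higher number a weaker inhibitor. Compound 2 `CO[C@H]1CC[C@H](Nc2cc(NCc3cnccc3C(F)(F)F)ncc2C#N)CC1`, its mirror image, returns only a limit in this assay, > 10000 nM. The step of an at least 2.0-fold higher number from compound 1 to compound 2 (0.30 log units; that floor lies within the scatter) rests on the limit of > 10000 nM in this assay, at which 1 of the 2 values shown sits, and (the fact that compounds 1 and 2 differ only in the configuration as drawn). Compound 3 `CO[C@H]1CC[C@H](CNc2cc(NCc3cnccc3C(F)(F)F)ncc2C#N)CC1` carries (4-methoxycyclohexyl)methyl in place of 4-methoxycyclohexyl on a nitrogen on an aromatic ring. For the measured compounds named here, no measured pair covers that change, so no step beyond the scatter is expected in this assay in either direction, and the limit of compound 2 supplies only a floor. Compound 3 is estimated at 10000 nM, between 3000 nM and 30000 nM. The expected step is a number no higher from compound 2 to compound 3 (the limit leaves the size open).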

Compound 3, half-maximal inhibitory concentration: > 10000 nM
Compound 3 was reported as a limit; the forecaster's own chance of this, stated with the estimate: 60%; the middle value sits exactly at the limit.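

Compound 3 is reported only as a limit, > 10000 nM, in this assay, so (4-methoxycyclohexyl)methyl on this nitrogen gives no value inside the measurable range. For the compounds shown here, the change read against the only numeric value gives an at least 2.0-fold higher number from compound 1 to compound 3 (0.30 log units; that floor lies within the scatter). The step from compound 2 cannot be read, because both values are limits: the limit of > 10000 nM in this assay, at which 2 of the 3 values shown sit.

Still open, from the compounds shown here alone, is whether (4-methoxycyclohexyl)methyl in the configuration drawn in compound 1 would give a number. Also open, going by these compounds, is how a 4-aminocyclohexyl or 4-carboxycyclohexyl group on this nitrogen would read.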